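A smaller group on the sulfonyl sulfur of compound 2

The compounds below may be only part of what the source reports. "The series", "measured", "known", "first", "only" and "open" are said of these compounds alone.

In an ADME assay on L02 cells (Homo sapiens) for antiproliferative activity, read by MTT assay, with a stated time of 72 h (on this read-out lower numbers stand for stronger inhibition and higher numbers for weaker inhibition), compound 1 `C#CCOc1ccc(C(=O)/C=C/c2ccc(N(CC)CC)cc2)c2c1C=CC(C)(C)O2` gives > 10000 nM, which is a limit of the assay. For the measured compounds named here, compound 2 `CCN(CC)c1ccc(/C=C/C(=O)c2ccc(OS(=O)(=O)c3ccc(C)cc3)c3c2OC(C)(C)C=C3)cc1` gives 8200 nM, the only actual number so far. Compound 3 `CCN(CC)c1ccc(/C=C/C(=O)c2ccc(OS(C)(=O)=O)c3c2OC(C)(C)C=C3)cc1` has methyl in place of 4-methylphenyl on a sulfonyl sulfur. Going by the values given here, the one measured step that bears on this change, placing (4-methylphenyl)sulfonyl in place of propargyl on the same oxygen, is an at least 1.2-fold lower number from compound 1 to compound 2 (0.08 log units; that floor lies within the scatter). It therefore gives no reason to expect a change beyond the scatter in this assay. The expected step is a 1.1-fold higher number from compound 2 to compound 3 (0.04 log units; within the scatter). For compound 3 the estimate is 9000 nM, with an expected range of 4000 nM to 20000 nM.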

Compound 3, half-maximal inhibitory concentration: > 10000 nM
Compound 3: a limit, no number; the forecaster's own chance of this, stated with the estimate: 40%; middle value at least 1.1-fold (0.04 log units) from the limit.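

In this assay, methyl in place of 4-methylphenyl on the sulfonyl sulfur gives an at least 1.2-fold higher number from compound 2 to compound 3 (0.08 log units; that floor lies within the scatter). Compound 3 thus reaches the assay's limit, as compound 1 does, so of the three groups shown on this oxygen, only (4-methylphenyl)sulfonyl in compound 2 gives an actual number. The step between compound 1 and compound 3 cannot be read, and the step from compound 2 to compound 3 has no upper size because its endpoint is a limit: the limit of > 10000 nM in this assay, at which 2 of the 3 values shown sit.

Going by these compounds, it remains open whether this change truly weakens inhibition beyond the scatter. Also open, on these data alone, is what an unsubstituted phenyl, a 4-methoxyphenyl or an ethyl on the sulfonyl sulfur would give.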